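The source may hold more compounds than are shown below. What is called first, only, known or untested is meant among the compounds shown, and "the series" means these compounds.

Compound 3, with the structure `C[C@@H]1CC(=O)NN=C1c1ccc(NC(=O)CCNC[C@@H](O)COc2ccc(CCOCC3CC3)cc2)cc1`, gives 0.9 umol/kg in a functional assay on the whole organism with Rattus norvegicus as the target; a lower number here means that less compound is needed, a higher number that more compound is needed for the effect. Among the three measured compounds it holds the lowest number, but only within the scatter of the others: compound 2, `C[C@@H]1CC(=O)NN=C1c1ccc(NC(=O)CCNC[C@H](O)COc2ccc(CCOCC3CC3)cc2)cc1`, gives 1 umol/kg in this assay, and compound 1, `CC1CC(=O)NN=C1c1ccc(NC(=O)CCNCC(O)COc2ccc(CCOCC3CC3)cc2)cc1`, gives 1.6 umol/kg. The steps between them are all small, with a 1.6-fold lower number from compound 1 to compound 2 (0.20 log units; within the scatter), a 1.8-fold lower number from compound 1 to compound 3 (0.25 log units; within the scatter) and a 1.1-fold lower number from compound 2 to compound 3 (0.05 log units; within the scatter).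

Compound 4 has the structure `C[C@H]1CC(=O)NN=C1c1ccc(NC(=O)CCNC[C@H](O)COc2ccc(CCOCC3CC3)cc2)cc1`. Relative to compound 3 the change is the two compounds have the same atoms and bonds and differ only in configuration as drawn: 2 of 2 stereo elements differ (all stereocentres are inverted: mirror images); a stereocentre at a saturated ring carbon is drawn R in compound 3 and S in compound 4; a stereocentre at a saturated chain carbon is drawn R in compound 3 and S in compound 4. Within the data shown here, of the measured steps, the one from compound 2 to compound 3 bears most directly on this, as the fact that compounds 2 and 3 differ only in the configuration as drawn shows that inverting the chain stereocentre alone left the number within the scatter. Among the measured compounds shown here, the inversion at the ring carbon has no measured counterpart, since compound 1 carries no defined configuration there. The expectation for compound 4 is therefore a step no larger than the scatter, with a 1.6-fold higher number from compound 3 to compound 4 (0.19 log units; within the scatter) as the estimated change. Compound 4 is expected to give 1.4 umol/kg in this assay, with a range from 0.5 umol/kg to 4 umol/kg.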

Compound 4, dose for half-maximal effect: > 40 umol/kg
Compound 4: a limit, no number; the forecaster's own chance of this, stated with the estimate: 5%; middle value at least 28-fold (1.45 log units) away from the limit.
By their numbers in this assay, from the lowest: compounds 3, 2 and 1 (each within the scatter of the next). At a limit, above all of these: compound 4.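

Compound 4 stands at a limit of this assay, > 40 umol/kg, which is not a number. The configuration at the saturated ring carbon therefore matters in a way that the chain carbon's did not: changing the ring carbon alone, from R to S, gives an at least 40-fold higher number from compound 2 to compound 4 (1.60 log units; beyond the scatter), while changing the chain carbon alone gave a 1.1-fold lower number from compound 2 to compound 3 (0.05 log units; within the scatter). Also large are an at least 44-fold higher number from compound 3 to compound 4 (1.64 log units; beyond the scatter) and an at least 25-fold higher number from compound 1 to compound 4 (1.39 log units; beyond the scatter), and compound 4 is the only one of the four drawn S at the ring carbon.

On these data alone, it remains open whether the chain carbon's configuration still makes no difference when the ring carbon is S, and how far beyond the limit compound 4 lies. Also open, as far as these compounds go, is whether an ethyl group or a plain hydrogen in place of the methyl on that ring carbon would keep the effect.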